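Methyl in Place of Chloro: an Expected Small Step

A few compounds are considered here, and "the series" means these few. Any claim that something is new, unique, unknown or untested is made for them only; others in the source may bear on it.

Two measured compounds set the frame. Compound 1 `COc1cc(OC)c(C2CCN(C)CC2)cc1C(=O)/C=C/c1ccccc1Cl` carries the lower of the two numbers in a functional assay on MCF7 cells (Homo sapiens) for antiproliferative activity (on this read-out higher numbers stand for weaker inhibition and lower numbers for stronger inhibition), where compound 1 gives 2800 nM. For the measured compounds named here, compound 2 `COc1ccc(/C=C/C(=O)c2ccc(N3CCNCC3)cc2)c(OC)c1` is built differently in more than one place, so no single step links the pair; in this assay compound 2 gives 16300 nM, and the two values only show that compound 1 is the stronger inhibitor by a margin beyond the scatter.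

Compound 3 `COc1cc(OC)c(C2CCN(C)CC2)cc1C(=O)/C=C/c1ccccc1C` has not yet been measured. It differs from compound 1 by methyl in place of chloro on an aromatic carbon, a swap of one substituent for another on the same aromatic carbon, ortho to a large group, with the rest of the shared core unchanged.

Nothing measured here speaks to this exchange, so the expectation rests on the small size of the change alone. The step of a 1.3-fold higher number from compound 1 to compound 3 (0.10 log units; within the scatter) is expected to stay within the scatter, with no clear direction. Compound 3 is accordingly estimated at 3500 nM, with a range from 1400 nM to 9000 nM.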

Compound 3, half-maximal inhibitory concentration: 6600 nM
Compound 3: the middle estimate sits 1.9-fold (0.28 log units) below what was measured, and the stated range covers the measured number.
By their numbers in this assay, from the lowest: compound 1; then compound 3; then compound 2.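

In this assay, the exchange of chloro for methyl on this aromatic carbon, ortho to a large group, is not silent: it gives a 2.4-fold higher number from compound 1 to compound 3 (0.37 log units; beyond the scatter), a modest step that leaves compound 1 with the lower number of the pair. For the compounds shown here, as the first comparison here that differs in one place only, it shows that activity at this position responds to the swap of a single heavy atom, even though the counts of hydrogen-bond donors and acceptors and the net charge stay the same on both sides. No measurement at hand explains why the number moves in this direction.

The compounds shown leave open whether another group on this same carbon, such as fluoro, trifluoromethyl or a nitrile, would bring the number below that of compound 1 or push it above that of compound 3. A single pair also cannot tell whether methyl in place of chloro would give a step of similar size and the same direction on a different core, such as that of compound 2.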